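This account rests on a few compounds, and the source may have more. Where it says the series, first, only, none or still open, it means among the compounds named here.

Compound 1 `O=C1Nc2ccc(F)cc2/C1=C\c1cccc(OCc2cn(Cc3ccccc3)nn2)c1` gives only a limit of the assay, > 50000 nM, in a functional assay on HeLa cells (Homo sapiens) for inhibition, read by MTT assay, with a stated time of 48 h; a lower number here means a stronger inhibitor, a higher number a weaker inhibitor.
Compound 2 `O=C1Nc2ccc([N+](=O)[O-])cc2/C1=C\c1cccc(OCc2cn(Cc3ccccc3)nn2)c1` likewise gives only a limit, > 50000 nM, in this assay.
Compound 3 `CC(=O)c1ccc2c(c1)/C(=C\c1cccc(OCc3cn(Cc4ccccc4)nn3)c1)C(=O)N2` also gives only a limit, > 50000 nM, in this assay.

All three values sit at the limit of > 50000 nM in this assay, at which 3 of the 3 values shown sit, so compound 3 stands nowhere readable among them, and the steps a step that the two limits leave unreadable from compound 1 to compound 2, a step that the two limits leave unreadable from compound 1 to compound 3 and a step that the two limits leave unreadable from compound 2 to compound 3 cannot be sized. Compound 4 `O=C1Nc2ccc(C(=O)c3ccccc3)cc2/C1=C\c1cccc(OCc2cn(Cc3ccccc3)nn2)c1` differs from compound 3 by phenyl in place of methyl on a carbonyl carbon. Among the compounds with values here, no measured step bears readably on this change; the only comparisons available concern substituents on an aromatic carbon of the shared core, and all of them are hidden by the limit. Compound 4 is therefore estimated at 60000 nM, within 10000 nM to 300000 nM. The step that the limit leaves unreadable from compound 3 to compound 4 is expected to be none beyond the scatter, most likely again a limit.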

Compound 4, half-maximal inhibitory concentration: > 50000 nM
Compound 4: no number, only a limit (the forecaster's own chance of this, stated with the estimate: 75%); the middle value lies beyond the limit too.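

Compound 4 also gives only a limit, so no step to it from compound 1, compound 2 or compound 3 can be read in this assay: the limit of > 50000 nM in this assay, at which 4 of the 4 values shown sit.

The compounds shown leave open whether any substituent on the shared core gives a readable value, and how far these four compounds differ.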